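A few compounds are considered here, and "the series" means these few. Any claim that something is new, unique, unknown or untested is made for them only; others in the source may bear on it.

In a functional assay, read by spectrophotometry, with a stated time of 5 min (a lower number here means a stronger inhibitor, a higher number a weaker inhibitor), compound 2 (`CCOc1cc(/C=C/C(=O)C(=Cc2ccc(O)c(O)c2)C(=O)/C=C/c2ccc(O)c(OCC)c2)ccc1O`) gives 3630 nM and compound 1 (`CCOc1cc(/C=C/C(=O)C(=Cc2ccc(O)c(OC)c2)C(=O)/C=C/c2ccc(O)c(OCC)c2)ccc1O`) gives 5360 nM, so the two stand level within the scatter. Compound 3 (`CCOc1cc(/C=C/C(=O)C(=Cc2ccc(OCC)c(OCC)c2)C(=O)/C=C/c2ccc(O)c(OCC)c2)ccc1O`) follows from compound 2 by 3,4-diethoxyphenyl in place of 3,4-dihydroxyphenyl on a double-bonded chain carbon bound to a double-bonded chain carbon. Among the compounds with values here, the only measured step bearing on this is a 1.5-fold lower number from compound 1 to compound 2 (0.17 log units; within the scatter), with hydrogen in place of methyl on an oxygen on an aromatic ring, and it stays within the scatter. Within the data shown here, no measured step covers ethyl on this ring, so a small move to a higher number is expected, possibly none beyond the scatter. The expected step is a 1.5-fold higher number from compound 2 to compound 3 (0.18 log units; within the scatter). For compound 3 the estimated value is 5500 nM, with a range of 2200 nM to 14000 nM.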

Compound 3, half-maximal inhibitory concentration: 20200 nM
Compound 3: the middle estimate sits 3.7-fold (0.56 log units) below what was measured; measured number outside the range, above it.
By their numbers in this assay, from the lowest: compounds 2 and 1 (each within the scatter of the next); then compound 3.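

In this assay the aryl group on a double-bonded chain carbon bound to a double-bonded chain carbon is not freely exchangeable: 3,4-diethoxyphenyl gives a 5.6-fold higher number from compound 2 to compound 3 (0.75 log units; beyond the scatter) and also a 3.8-fold higher number from compound 1 to compound 3 (0.58 log units; beyond the scatter), both beyond the scatter, while the step between the two hydroxy-bearing compounds stayed within it. Of the three aryl groups, only 3,4-diethoxyphenyl carries no hydroxy group. No supporting data bear on the origin of this rise. Still open, as far as these compounds go, is whether the ethyl groups or the missing hydroxy groups drive it; 3,4-dimethoxyphenyl or a longer chain such as 3,4-dipropoxyphenyl would test this.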